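Methylating the ring amine of compound 2

This account rests on a few compounds, and the source may have more. Where it says the series, first, only, none or still open, it means among the compounds named here.

In a functional assay on U-937/GTB cells (Homo sapiens) for cytotoxicity (a lower number here means a stronger inhibitor, a higher number a weaker inhibitor), compound 1 (`CC(C)=CCC/C(C)=C\CC/C(C)=C/C[n+]1cn(C)c2nc[nH]/c(=N\OCc3ccccc3)c21`) gives 7550 nM as its half-maximal inhibitory concentration. Compound 2 (`CC(C)=CCC/C(C)=C/CC/C(C)=C/CC/C(C)=C/Cn1cnc2c1C(=N)NCN2C`) shows > 80000 nM as a limit only and not a number. Compound 3 (`CC(C)=CCC/C(C)=C/CC/C(C)=C/CC/C(C)=C/Cn1cnc2c1C(=N)N(C)CN2C`) differs from compound 2 by methyl in place of hydrogen on an amine nitrogen in a ring with methyl in place of hydrogen on an amine nitrogen in a ring. Within the data shown here, no measured step covers this change in this assay so no shift beyond the scatter is expected, in either direction. The expected move is a number no higher from compound 2 to compound 3 (the limit leaves the size open) as an estimate only. Compound 3 is estimated at 80000 nM with compound-level uncertainty (expected range 25000 nM to 160000 nM).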

Compound 3, half-maximal inhibitory concentration: 3360 nM
Estimate against measurement, compound 3: 24-fold (1.38 log units) above; measured number below the stated range.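

In this assay, among these compounds, methyl in place of hydrogen on an amine nitrogen in a ring gives the first single-place comparison, with an at least 23-fold lower number from compound 2 to compound 3 (1.37 log units; beyond the scatter). This ring nitrogen is therefore sensitive to substitution, with methyl and hydrogen separated beyond the scatter. The size of this step remains a minimum, since compound 2 has a limit and not a number: the limit of > 80000 nM in this assay, at which 1 of the 3 values shown sits.

Open, going by these compounds, is whether the trend stops at methyl or continues with an ethyl group or a longer chain on this nitrogen. Also open, on these data alone, is how an acetyl group there would compare.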